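The source may hold more compounds than are shown below. What is called first, only, known or untested is meant among the compounds shown, and "the series" means these compounds.

Going by the values given here, compound 3, `CCOC(=O)/C=C\NC(=O)[C@@H](O)C(C)(C)CO`, sits in the middle of the three numbers measured so far: in an ADME assay on WI-38 cells (Homo sapiens) for inhibition, read by CellTiter-Glo, with a stated time of 48 h, tested at 100 uM (on this read-out higher numbers stand for more inhibition at the one concentration tested (going by the name of the read-out) and lower numbers for less inhibition), compound 3 gives -6%. The nearest neighbour is compound 1, `COC(=O)/C=C/NC(=O)[C@@H](O)C(C)(C)CO`, which in this assay gives -18%, a number beyond the scatter below compound 3. The furthest is compound 2, `CC(C)(C)OC(=O)/C=C\NC(=O)[C@@H](O)C(C)(C)CO`, which in this assay gives 26%. Among the compounds with values here, the one step between measured compounds runs from compound 2 to compound 3, where ethyl takes the place of tert-butyl on an oxygen next to a carbonyl group, and it gave a number 32 percentage points lower from compound 2 to compound 3 (beyond the scatter).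

The next compound is compound 4, `COC(=O)/C=C\NC(=O)[C@@H](O)C(C)(C)CO`. It differs from compound 3 in one place: hydrogen in place of methyl on a saturated chain carbon bound to an oxygen next to a carbonyl group. The change shortens the same chain that was already shortened from compound 2 to compound 3, so that step is the only one that bears on it; it was large and downward. A smaller step downward is therefore expected in this assay, estimated as a number 8 percentage points lower from compound 3 to compound 4 (within the scatter). Compound 4 is expected to come out near -14%, within a range from -30% to 2%.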

Compound 4, a percentage reported as inhibition, at one concentration (the size of the read-out at that concentration, not a potency): -20%
Estimate against measurement, compound 4: 6 percentage points above; the range from low to high includes it.
By their numbers in this assay, from the lowest: compounds 4 and 1 (each within the scatter of the next); then compound 3; then compound 2.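

Going from ethoxycarbonyl to methoxycarbonyl moves the number further down in this assay, with a number 14 percentage points lower from compound 3 to compound 4 (beyond the scatter), so the change is not exhausted once tert-butyl gives way to ethyl. Across the whole series, methyl in place of tert-butyl gives a number 46 percentage points lower from compound 2 to compound 4 (beyond the scatter), and the numbers for compounds 2, 3 and 4 follow the size of this group, with none of the three going against that order. The drawn geometry of the double bond, however, shows no step beyond the scatter, with a number 2 percentage points lower from compound 1 to compound 4 (within the scatter), and this pair tests that one feature alone: the fact that compounds 1 and 4 differ only in the configuration as drawn

Going by these compounds, whether a longer chain, such as n-butyl, or a branched isopropyl would fall on the same trend remains open, as does what a carboxylic acid would give at this position. On these data alone, it is also open whether the double-bond geometry would matter as little with tert-butyl in place of methyl.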